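Working notes: cytotoxicity of compound 4 against the series

This account rests on a few compounds, and the source may have more. Where it says the series, first, only, none or still open, it means among the compounds named here.

Measured so far:
Compound 1 `COc1ccc(C(O)C2OC(=O)c3c(OC)cc(OC)cc32)cc1` gives > 40000 nM in an ADME assay on RAW264.7 cells (Mus musculus) for cytotoxicity, read by MTT assay, with a stated time of 24 h, in the absence of a further agent (on this read-out higher numbers stand for weaker inhibition and lower numbers for stronger inhibition), a limit of the assay rather than a number.
Compound 2 `CCOc1ccc(C(O)C2OC(=O)c3c(OC)cc(OC)cc32)cc1` gives > 40000 nM in this assay, again a limit.
Compound 3 `COc1cc(OC)c2c(c1)C(C(O)c1ccc(OCc3ccc(Cl)cc3)cc1)OC2=O` gives > 40000 nM in this assay, again a limit.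

Compound 2 therefore stands only at a limit, and the two further values shown sit at the same limit (the limit of > 40000 nM in this assay, at which 3 of the 3 values shown sit). On these data alone, the steps a step that the two limits leave unreadable from compound 1 to compound 2, a step that the two limits leave unreadable from compound 1 to compound 3 and a step that the two limits leave unreadable from compound 2 to compound 3 are left unreadable by these limits, so their sizes and directions are unknown.

Compound 4 `COc1cc(OC)c2c(c1)C(C(O)c1ccc(OCc3ccc(C)cc3)cc1)OC2=O` differs from compound 2 by 4-methylphenyl in place of methyl on a saturated chain carbon bound to an oxygen on an aromatic ring. The measured step nearest to this change is a step that the two limits leave unreadable from compound 2 to compound 3, 4-chlorophenyl in place of methyl on a saturated chain carbon bound to an oxygen on an aromatic ring, but its size cannot be read. With every step in this assay unreadable, no movement beyond the scatter can be expected in either direction.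

Compound 4 is expected to remain at the limit, estimated at 60000 nM with a range from 40000 nM to 120000 nM. The step that the limit leaves unreadable from compound 2 to compound 4 is thus expected to be nothing beyond the scatter.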

Compound 4, half-maximal inhibitory concentration: > 40000 nM
Compound 4 ended at the assay's limit (the forecaster's own chance of this, stated with the estimate: 85%); the middle value lies beyond the limit too.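

Compound 4 sits at a limit, as do compound 1, compound 2 and compound 3, so no step among these four compounds can be read: the limit of > 40000 nM in this assay, at which 4 of the 4 values shown sit.

The compounds shown leave open what concentration, if any, would give a numerical value for any of them in this assay.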